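This account rests on a few compounds, and the source may have more. Where it says the series, first, only, none or still open, it means among the compounds named here.

Compound 1 `COc1cc(-n2cncc2-c2ccc(N)cc2)cc(OC)c1OC`: 7260 nM
Compound 2 `COc1ccc(-c2ocnc2-c2cc(OC)c(OC)c(OC)c2)cc1N`: 11 nM

In a functional assay on HCT-15 cells (Homo sapiens) for inhibition (on this read-out higher numbers stand for weaker inhibition and lower numbers for stronger inhibition), compound 1 stands highest at 7260 nM. Compound 2 gives 11 nM on the side of stronger inhibition. The gap between these two compounds lies far beyond the usual scatter. Compound 3 `COc1cc(-n2cncc2-c2ccc(N(C)C)cc2)cc(OC)c1OC` keeps the core of compound 1 and carries dimethylamino in place of amino on an aromatic carbon, para to a large group (dimethylamino in place of amino on an aromatic carbon). Among the measured compounds shown here, no measured step of this kind is available, so the expectation rests on the structural change alone. A modest move toward stronger inhibition in this assay is expected, with a 2.4-fold lower number from compound 1 to compound 3 (0.38 log units; beyond the scatter) as the estimated step. Compound 3 is estimated at 3000 nM with an expected range from 500 nM to 15000 nM on this read-out.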

Compound 3, half-maximal inhibitory concentration: 36 nM
Beside the measured number, compound 3's estimate is 83-fold (1.92 log units) above it; measured number outside the range, below it.
By their numbers in this assay, from the lowest: compound 2; then compound 3; then compound 1.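

In this assay, dimethylamino in place of amino on this aromatic carbon, para to a large group, gives a 200-fold lower number from compound 1 to compound 3 (2.30 log units; beyond the scatter), so inhibition on the core of compound 1 responds strongly to the group at this place. The entering group carries 0 hydrogen-bond donors, so a donor here is not required for the stronger inhibition of compound 3. Nothing in the available data explains the size of this step. The compounds shown leave open whether methylamino would give a similar step, and how diethylamino or pyrrolidine would compare at this place.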